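From 3-methylphenyl to 3-methoxyphenyl

A few compounds are considered here, and "the series" means these few. Any claim that something is new, unique, unknown or untested is made for them only; others in the source may bear on it.

In a functional assay on HeLa cells (Homo sapiens) for antiproliferative activity, read by MTT assay, with a stated time of 72 h (on this read-out higher numbers stand for weaker inhibition and lower numbers for stronger inhibition), compound 1 (`CCCn1ccnc1-c1cc(OC)c(OC)c(OC)c1`) gives only a limit of the assay (> 100000 nM) and not a number. For the measured compounds named here, compound 2 (`COc1cc(-c2nccn2-c2cccc(C)c2)cc(OC)c1OC`) gives 1900 nM in this assay and so holds the only actual number so far. Going by the values given here, the one measured step is an at least 52-fold lower number from compound 1 to compound 2 (1.72 log units; beyond the scatter) and comes with 3-methylphenyl in place of propyl on an aromatic nitrogen. Compound 3 (`COc1cccc(-n2ccnc2-c2cc(OC)c(OC)c(OC)c2)c1`) instead carries methoxy in place of methyl on an aromatic carbon, meta to a large group (methoxy in place of methyl on an aromatic carbon). The measured step replaces the whole group on that nitrogen, whereas this change keeps a 3-substituted phenyl, so its large size does not carry over. The expected result is a 1.1-fold lower number from compound 2 to compound 3 (0.05 log units; within the scatter) in this assay and thus no change beyond the scatter. Compound 3 is expected at 1700 nM (estimated range 500 nM to 6000 nM).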

Compound 3, half-maximal inhibitory concentration: 11000 nM
Compound 3: the middle estimate sits 6.5-fold (0.81 log units) below what was measured; the measured number lies above the stated range.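

In this assay, this place on the phenyl ring proves not to be indifferent to its substituent: with the ring kept and only methyl exchanged for methoxy, the change gives a 5.8-fold higher number from compound 2 to compound 3 (0.76 log units; beyond the scatter). The earlier step showed only what replacing propyl as a whole group does, whereas this one separates two 3-substituted phenyl groups from each other. The 3-methoxyphenyl group still reads better than propyl on that nitrogen, with an at least 9.0-fold lower number from compound 1 to compound 3 (0.95 log units; beyond the scatter), but compound 1 gives a limit and not a number, so this step is a bound and not an exact size: the limit of > 100000 nM in this assay, at which 1 of the 3 values shown sits.

The compounds shown leave open how a chlorine, a hydroxyl or an ethyl group would read at this same place. They also leave open whether an unsubstituted phenyl on that nitrogen would stand closer to compound 2 or to compound 3.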